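A few compounds are considered here, and "the series" means these few. Any claim that something is new, unique, unknown or untested is made for them only; others in the source may bear on it.

Measured compounds:
compound 1 `Cn1c(-c2ccc(NC(=O)CSc3nc4cc(Cl)ccc4o3)cc2)nc(-c2ccccc2)c1-c1ccccc1` gives 27.7% in a functional assay on MCF7 cells (Homo sapiens) for cytotoxicity, read by MTT assay, with a stated time of 24 h, tested at 6.4 ug/mL; on this read-out higher numbers stand for a stronger effect at the one concentration tested and lower numbers for a weaker effect
compound 2 `Cn1cnnc1SCC(=O)Nc1ccc(-c2nc(-c3ccccc3)c(-c3ccccc3)n2C)cc1` gives 59.2%
compound 3 `CN1CCN(CC(=O)Nc2ccc(-c3nc(-c4ccccc4)c(-c4ccccc4)n3C)cc2)CC1` gives 28.6%

Compound 1 stands at the low end of the three numbers, but not clearly apart from all of them: compound 3 is a number 0.9 percentage points higher from compound 1 to compound 3 (within the scatter), a gap within the scatter, while compound 2 is a number 31.5 percentage points higher from compound 1 to compound 2 (beyond the scatter), well beyond it. Among the compounds with values here, the one large step measured so far, a number 30.6 percentage points lower from compound 2 to compound 3 (beyond the scatter), shows that what sits on the saturated chain carbon bound to the carbonyl carbon can move the read-out in this assay a long way.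

Compound 4 `CN(C)/C=C/N1CCN(CC(=O)Nc2ccc(-c3nc(-c4ccccc4)c(-c4ccccc4)n3C)cc2)CC1` is not yet measured. It differs from compound 1 by 4-(2-(dimethylamino)ethenyl)piperazin-1-yl in place of (5-chloro-1,3-benzoxazol-2-yl)sulfanyl on a saturated chain carbon bound to a carbonyl carbon. Of the measured steps, a number 0.9 percentage points higher from compound 1 to compound 3 (within the scatter) bears most directly on it, since compound 3 already carries the 4-methylpiperazin-1-yl group at that place and its number lay within the scatter of compound 1. The step of a number 31.5 percentage points higher from compound 1 to compound 2 (beyond the scatter) concerns a different group and offers no guide here. Within the data shown here, compound 4 extends the piperazine of compound 3 by a 2-(dimethylamino)ethenyl group, a change for which no measured pair exists.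

Compound 4 is therefore expected to land close to compound 1 and compound 3, with a step of a number 2.3 percentage points higher from compound 1 to compound 4 (within the scatter) that stays within the scatter. The estimated value for compound 4 is 30%, expected to fall between 15% and 50%.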

Compound 4, a percentage reported as activity, at one concentration (the size of the read-out at that concentration, not a potency): 11.1%
Compound 4: middle estimate off by 18.9 percentage points, on the high side; the whole stated range lies above it.
By their numbers in this assay, from the lowest: compound 4; then compounds 1 and 3 (each within the scatter of the next); then compound 2.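

In this assay, the group on the saturated chain carbon bound to a carbonyl carbon proves sensitive to a change further out on the piperazine: 2-(dimethylamino)ethenyl in place of methyl on the amine nitrogen in the ring gives a number 17.5 percentage points lower from compound 3 to compound 4 (beyond the scatter), so keeping the piperazine alone does not preserve the level that had not been told apart from compound 1. Against the two sulfanyl groups the new group also falls beyond the scatter, with a number 16.6 percentage points lower from compound 1 to compound 4 (beyond the scatter) and a number 48.1 percentage points lower from compound 2 to compound 4 (beyond the scatter), which leaves compound 4 the lowest of the four and widens the range this position is known to span. Nothing measured here accounts for the drop.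

The compounds shown leave open whether the step belongs to the double bond or to the dimethylamino end, since compound 4 brings both together, and a saturated 2-(dimethylamino)ethyl chain on the same ring nitrogen would separate the two. They also leave open how a morpholine in place of the piperazine would read at this position.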